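Aryl variation on the pyrazole carboxylic acid series

This account rests on a few compounds, and the source may have more. Where it says the series, first, only, none or still open, it means among the compounds named here.

Measured so far in a functional assay on BJAB cells (Homo sapiens) for antiproliferative activity, with a stated time of 4 days; on this read-out lower numbers stand for an effect already at smaller amounts and higher numbers for an effect only at larger amounts of compound:
- compound 1 `Cc1nn(-c2nc(-c3ccc(Cl)c(Cl)c3)c(SC(C)C)s2)c(C(=O)O)c1-c1cccc(F)c1`: compound 1 gives 900 nM
- compound 2 `Cc1cc(C#N)cc(-c2c(C)nn(-c3nc(-c4ccc(Cl)c(Cl)c4)c(SC(C)C)s3)c2C(=O)O)c1`: compound 2 gives 4800 nM
- compound 3 `COc1ccccc1-c1c(C)nn(-c2nc(-c3ccc(Cl)c(Cl)c3)c(SC(C)C)s2)c1C(=O)O`: compound 3 gives 14700 nM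

Compound 3 holds the highest number of the three; its steps to both others are beyond the scatter: a 16-fold higher number from compound 1 to compound 3 (1.21 log units; beyond the scatter) and a 3.1-fold higher number from compound 2 to compound 3 (0.49 log units; beyond the scatter). The remaining step, a 5.3-fold higher number from compound 1 to compound 2 (0.73 log units; beyond the scatter), is the smaller of the three.

Compound 4 `Cc1cc(-c2c(C)nn(-c3nc(-c4ccc(Cl)c(Cl)c4)c(SC(C)C)s3)c2C(=O)O)cc(C)n1` arises from compound 3 by 2,6-dimethylpyridin-4-yl in place of 2-methoxyphenyl on an aromatic carbon. Going by the values given here, no measured step covers this exchange directly. What the three steps do show is that every change of the aryl group moved the read-out beyond the scatter, so a change of similar size should be expected here too. The group entering carries two methyl substituents, as the group of compound 2 carries two substituents, while the group leaving carries one; compound 2 stands well below compound 3 in this assay. On that ground compound 4 is expected to land nearer compound 2 than compound 3, an expected step of a 3.3-fold lower number from compound 3 to compound 4 (0.51 log units; beyond the scatter). The estimate for compound 4 in this assay is 4500 nM, with a range from 1500 nM to 13000 nM.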

Compound 4, half-maximal effective concentration: 580 nM
The estimate for compound 4 lay 7.8-fold (0.89 log units) above the measured number, and the stated range ends above it.
By their numbers in this assay, from the lowest: compounds 4 and 1 (each within the scatter of the next); then compound 2; then compound 3.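

Going by these compounds alone, at this position, on an aromatic carbon next to the ring atom that bears a carboxy group, the first aromatic ring with 1 hetero atom gives in this assay a 25-fold lower number from compound 3 to compound 4 (1.40 log units; beyond the scatter), the largest step so far, and an 8.3-fold lower number from compound 2 to compound 4 (0.92 log units; beyond the scatter). The 2,6-dimethylpyridin-4-yl group also gives a 1.6-fold lower number from compound 1 to compound 4 (0.19 log units; within the scatter), so two substituents on the aryl ring do not by themselves set the read-out: compound 2 and compound 4 both carry two, yet their numbers lie well apart. Nothing available on these compounds offers an explanation for these steps.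

The share of the hetero atom and of the two methyl groups remains unresolved. An unsubstituted pyridin-4-yl group and a 3,5-dimethylphenyl group would separate them, and an amino group on the pyridine ring would test how far this ring can be varied.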